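The source may report more compounds than this note shows. Statements on the series, on what has been measured and on what is new or still open speak of the compounds shown alone.

Compound 1, `C[Se]/C(=N\C(=O)c1ccco1)NC(=O)c1ccco1`: > 100000 nM
Compound 2, `CS/C(=N\C(=O)c1cc(-c2ccccc2)nc2ccccc12)NC(=O)c1cc(-c2ccccc2)nc2ccccc12`: > 100000 nM
Compound 3, `C[Se]/C(=N\C(=O)c1cnc2ccccc2c1)NC(=O)c1cnc2ccccc2c1`: 60700 nM

All three were tested in a functional assay on MCF7 cells (Homo sapiens) for cytotoxicity, read by MTT assay, with a stated time of 72 h; a higher number here means that more compound is tolerated, a lower number that less compound is tolerated. Compound 1 reaches only a limit of the assay, > 100000 nM, not a number. Compound 2 likewise reaches only a limit, > 100000 nM. For the measured compounds named here, compound 3 is the one compound of the three that gives a real number, 60700 nM, and so it stands alone among the values shown. The other two sit at the limit described by the limit of > 100000 nM in this assay, at which 2 of the 3 values shown sit, so no ranking between them and compound 3 can be read beyond the fact that compound 3 was measurable.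

Compound 4, `CS/C(=N\C(=O)c1cnc2ccccc2c1)NC(=O)c1cnc2ccccc2c1`, has not yet been measured in this assay. It differs from compound 3 in one place: a group of 2 heavy atoms (1 carbon, 1 sulfur; no ring) in place of a group of 2 heavy atoms (1 carbon, 1 selenium; no ring), on a carbon with a double bond to nitrogen; in words, a group of 2 heavy atoms (1 carbon, 1 sulfur; no ring) in place of a group of 2 heavy atoms (1 carbon, 1 selenium; no ring), on a carbon with a double bond to nitrogen.

Going by the values given here, no measured pair shows this exchange directly. Among the compounds with values here, compound 1 and compound 2 carry the two groups in question but both sit at the limit, so they give no size for the step. The expected step from compound 3 to compound 4 is therefore small, a 1.3-fold higher number from compound 3 to compound 4 (0.12 log units; within the scatter), probably within the scatter or slightly towards more compound tolerated. Compound 4 is thus estimated at 80000 nM, with a range from 35000 nM to 200000 nM.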

Compound 4, concentration lethal to 50% of the cells: > 100000 nM
Compound 4: a limit, no number (the forecaster's own chance of this, stated with the estimate: 40%); middle value at least 1.2-fold (0.09 log units) from the limit.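

Compound 3 and compound 4 are the first pair shown that differ in one place only, so the exchange of the group of carbon and selenium for methylsulfanyl, on a carbon with a double bond to nitrogen, can now be read directly rather than guessed from compounds that differ elsewhere as well. In this assay this exchange gives an at least 1.6-fold higher number from compound 3 to compound 4 (0.21 log units; that floor lies within the scatter), which is a floor and not a full measure, so the step could be small or much larger than that floor. For the compounds shown here, compound 4 gives only a limit of the assay and no number, which leaves compound 3 as the one measurable compound and adds one more to the group at that limit: the limit of > 100000 nM in this assay, at which 3 of the 4 values shown sit.

On these data alone, the true size of the step stays open, as does the question of whether the same exchange would read alike on a different core, where both partners might give real numbers. Also open, as far as these compounds go, is what other groups in this place would do, such as an amine or a longer chain like ethylsulfanyl.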